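A Chloroalkyl Anilide in Place of an Acylurea

The source may report more compounds than this note shows. Statements on the series, on what has been measured and on what is new or still open speak of the compounds shown alone.

Compound 1 `CCCCC(OC)c1cccc(NC(=O)NC(=O)CCl)c1`: in a functional assay on HT-29 cells (Homo sapiens) for antiproliferative activity, with a stated time of 48 h (a higher number here means a weaker inhibitor, a lower number a stronger inhibitor), compound 1 gives 10000 nM.
Compound 2 `CCCCC(O)c1cccc(NC(=O)NC(=O)CC)c1`: in this assay compound 2 reaches only the assay limit, > 100000 nM.
Compound 3 `CCCCC(OC)c1cccc(NC(=O)NC(=O)CC)c1`: in this assay compound 3 also reaches only the assay limit, > 100000 nM.

Compound 3 therefore stands at the limit of > 100000 nM in this assay, at which 2 of the 3 values shown sit, and no number is known for it. Compound 4 `CCCCC(OC)c1cccc(NC(=O)CCCl)c1` differs from compound 3 by 2-chloroethyl in place of propanoylamino on a carbonyl carbon. Within the data shown here, two measured steps touch on this. The step of an at least 10-fold higher number from compound 1 to compound 3 (1.00 log units; beyond the scatter) shows the number rising when chloro is replaced by methyl on the chain. The step that the two limits leave unreadable from compound 2 to compound 3 gives no readable size. Given an at least 10-fold higher number from compound 1 to compound 3 (1.00 log units; beyond the scatter), compound 4, which again carries chlorine on its chain, is expected to give 50000 nM, within 8000 nM to 200000 nM. The step this estimate implies, an at least 2.0-fold lower number from compound 3 to compound 4 (0.30 log units; that floor lies within the scatter), is an expectation only, and a further limit remains quite possible.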

Compound 4, half-maximal inhibitory concentration: > 100000 nM
Compound 4: only a limit was reported; the forecaster's own chance of this, stated with the estimate: 50%; at least 2.0-fold (0.30 log units) between middle value and limit.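

In this assay, 2-chloroethyl in place of ((chloromethyl)carbonyl)amino on the carbonyl carbon gives an at least 10-fold higher number from compound 1 to compound 4 (1.00 log units; beyond the scatter), so a chlorine-bearing chain on this carbon does not by itself keep the activity of compound 1. Compound 4 reaches only a limit of the assay, > 100000 nM, and its step with compound 3 cannot be read. Compound 4 therefore joins the compounds without a number: the limit of > 100000 nM in this assay, at which 3 of the 4 values shown sit.

On these data alone, how far compound 2, compound 3 and compound 4 lie past that limit stays open. So does whether an amine or a longer chloroalkyl chain on this carbonyl carbon would restore a measurable value.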